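A few compounds are considered here, and "the series" means these few. Any claim that something is new, unique, unknown or untested is made for them only; others in the source may bear on it.

Measured so far in a functional assay on a cell-free system (Platelet, plasma, Homo sapiens) for inhibition (a higher number here means a weaker inhibitor, a lower number a stronger inhibitor), and no other assay:
compound 1 `COc1cccc(C(=O)N(CCN2CCC(OCC(=O)O)CC2)c2ccc(C)cc2)c1` gives 32 nM
compound 2 `O=C(O)COC1CCN(CCN(C(=O)c2cccc(F)c2)c2ccc(Cl)cc2)CC1` gives 340 nM

Compound 2 has the higher number of the two, beyond the scatter from compound 1, so it is the weaker inhibitor of this pair. Compound 3 `COc1cccc(C(=O)N(CCN2CCC(OCC(=O)O)CC2)c2ccc(Cl)cc2)c1` is still to be measured. It carries methoxy in place of fluoro on an aromatic carbon, meta to a large group, relative to compound 2 (methoxy in place of fluoro on an aromatic carbon).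

Going by the values given here, no measured pair isolates this change, so its size cannot be read directly. Among the compounds with values here, the only guide is compound 1, which also bears the 3-methoxyphenyl group and gives 32 nM in this assay with the lower number. Compound 1 and compound 2 do not differ in just one place, so that gap cannot be assigned to the methoxy alone. A move to a lower number, beyond the scatter but short of the whole gap, is expected, with a 4.9-fold lower number from compound 2 to compound 3 (0.69 log units; beyond the scatter) as the working figure. The estimate for compound 3 is 70 nM, with an expected range of 25 nM to 220 nM.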

Compound 3, half-maximal inhibitory concentration: 74 nM
The estimate for compound 3 lay 1.1-fold (0.02 log units) below the measured number, within the range that was stated.
By their numbers in this assay, from the lowest: compound 1; then compound 3; then compound 2.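

In this assay, going by these compounds alone, methoxy in place of fluoro on an aromatic carbon, meta to a large group, gives a 4.6-fold lower number from compound 2 to compound 3 (0.66 log units; beyond the scatter); this is the first reading of this change with nothing else in the structure altered, and it shows that the position responds to the group it carries. Compound 3 also isolates a second place, where chloro in place of methyl on an aromatic carbon gives a 2.3-fold higher number from compound 1 to compound 3 (0.36 log units; beyond the scatter), so with both steps beyond the scatter, the gap between compound 1 and compound 2 belongs to two places and not to the methoxy alone. No measurement here bears on why either change moves the number, so the steps stand as observations only.

The compounds shown leave open whether the methoxy step holds at the same size when methyl stands in place of chloro, since only one such pair can be read. Within the data shown here, they also leave open how this position responds to other groups, such as ethoxy, hydroxyl, an amine or a nitrile, and so whether methoxy is a particular optimum or only one of several groups that lower the number.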